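The compounds below may be only part of what the source reports. "The series", "measured", "known", "first", "only" and "open" are said of these compounds alone.

Working notes on the series. Compound 1 `Cc1ccc(-c2cn3nc(Cc4ccc(Cl)cc4)sc3n2)cc1` is known in a functional assay on HeLa cells (Homo sapiens) for cytotoxicity, with a stated time of 72 h (a higher number here means a weaker inhibitor, a lower number a stronger inhibitor), only as a limit: compound 1 gives > 250000 nM. Compound 2 `O=[N+]([O-])c1ccc(-c2cn3nc(Cc4ccc(Cl)cc4)sc3n2)cc1` likewise returns a limit in this assay, with compound 2 at > 250000 nM. The step that the two limits leave unreadable from compound 1 to compound 2 therefore cannot be sized, and the limit of > 250000 nM in this assay, at which 2 of the 2 values shown sit, is all the two values show. Compound 3 `Cc1ccc(-c2nc3sc(Cc4ccc(Cl)cc4)nn3c2Br)cc1` differs from compound 1 by bromo in place of hydrogen on an aromatic carbon. Among the compounds with values here, no measured step reports on a bromo at this place, and the single recorded step stays unreadable. Compound 3 is expected near 200000 nM in this assay, within 50000 nM to 400000 nM. The expected step is an at least 1.2-fold lower number from compound 1 to compound 3 (0.09 log units; that floor lies within the scatter).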

Compound 3, half-maximal inhibitory concentration: > 250000 nM
Compound 3 was reported as a limit; the forecaster's own chance of this, stated with the estimate: 70%; middle value at least 1.2-fold (0.09 log units) away from the limit.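

The step from compound 1 to compound 3 cannot be read, as both values are limits: the limit of > 250000 nM in this assay, at which 3 of the 3 values shown sit. The compounds shown leave open whether the bromo or nitro change has any effect in this assay.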